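The source may report more compounds than this note shows. Statements on the series, on what has been measured and on what is new or still open speak of the compounds shown alone.

In a functional assay on aorta (Rattus norvegicus) for inhibition (on this read-out higher numbers stand for an effect only at larger amounts of compound and lower numbers for an effect already at smaller amounts), the measured compounds are:

- Compound 1 `CC(C)NC1=NS(=O)(=O)c2ccc(Cl)cc2N1`: 53400 nM
- Compound 2 `O=S1(=O)N=C(NC2CC2)Nc2cc(Cl)ccc21`: 156000 nM
- Compound 3 `CCNC1=NS(=O)(=O)c2c(Cl)cccc2N1`: > 300000 nM, a limit

Compound 3 has only a limit and no number, and this is the limit of > 300000 nM in this assay, at which 1 of the 3 values shown sits. Compound 4 `CCCNC1=NS(=O)(=O)c2c(Cl)cccc2N1` replaces its ethyl with propyl, a change given by methyl in place of hydrogen on a saturated chain carbon, two bonds along the chain from an amine nitrogen. For the measured compounds named here, the one measured step, a 2.9-fold higher number from compound 1 to compound 2 (0.47 log units; beyond the scatter), concerns a different change on a different core, so it bears only loosely, but it suggests that a chain change moves the number modestly. A modest move towards a lower number is therefore expected, although the result may remain a limit. The expected step is an at least 1.2-fold lower number from compound 3 to compound 4 (0.07 log units; that floor lies within the scatter). For compound 4 the estimate is 250000 nM, with an expected range from 100000 nM to 500000 nM.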

Compound 4, half-maximal effective concentration: > 300000 nM
Compound 4: no number, only a limit; the forecaster's own chance of this, stated with the estimate: 50%; middle value at least 1.2-fold (0.07 log units) from the limit.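

In this assay, for the compounds shown here, compound 3 and compound 4 both give only a limit, so no step between them can be read. The compounds shown leave open whether ethyl to propyl shifts the number at all.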